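This account rests on a few compounds, and the source may have more. Where it says the series, first, only, none or still open, it means among the compounds named here.

Measured compounds:
compound 1 `CNC(=O)Nc1ccc(-c2nc(N3CC4CCC(C3)O4)c3sc(CN4CCN(S(C)(=O)=O)CC4)cc3n2)cc1` — 120 nM
compound 2 `CS(=O)(=O)N1CCN(Cc2cc3nc(-c4ccc(NC(=O)NC5CC5)cc4)nc(N4CC5CCC(C4)O5)c3s2)CC1` — 32 nM

Both were run in a functional assay on LNCaP cells (Homo sapiens) for cytotoxicity; a lower number here means a stronger inhibitor, a higher number a weaker inhibitor. In this assay, among the compounds with values here, compound 1 stands at the higher of the two numbers; its only neighbour is compound 2, reached by a 3.8-fold lower number from compound 1 to compound 2 (0.57 log units; beyond the scatter), the change being cyclopropyl in place of methyl on an amide-type nitrogen.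

Compound 3 `CNC(=O)Nc1ccc(-c2nc(N3CC4CCC(C3)O4)c3sccc3n2)cc1` is not yet measured. It differs from compound 1 by hydrogen in place of (4-(methylsulfonyl)piperazin-1-yl)methyl on an aromatic carbon of a five-membered aromatic ring with one sulfur, part of a fused or bridged system of two rings, next to the ring sulfur. Within the data shown here, no measured step bears on this change: the one step available alters the urea end of the molecule and leaves the group now removed untouched. The direction is therefore open. As a working assumption, a step of modest size toward a higher number, possibly no larger than the scatter, is taken. For compound 3 the expected value is 220 nM, with a range of 60 nM to 800 nM. Expected, therefore, is a 1.8-fold higher number from compound 1 to compound 3 (0.26 log units; within the scatter).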

Compound 3, half-maximal inhibitory concentration: 85 nM
Beside the measured number, compound 3's estimate is 2.6-fold (0.41 log units) above it; the measured number falls inside the stated range.
By their numbers in this assay, from the lowest: compound 2; then compounds 3 and 1 (each within the scatter of the next).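

In this assay hydrogen in place of (4-(methylsulfonyl)piperazin-1-yl)methyl on this aromatic carbon, next to the ring sulfur, gives a 1.4-fold lower number from compound 1 to compound 3 (0.15 log units; within the scatter) and so stands within the scatter. For the methyl urea pair, the whole group, with its 11 heavy atoms and six-membered non-aromatic ring, can therefore go without a difference that can be told from the scatter, a point the earlier step at the urea end could not address; this rests on one pair only. No measurement at hand offers an explanation for this outcome.

Open, going by these compounds, is how the cyclopropyl urea of compound 2 behaves with hydrogen on this carbon, and so whether the step at the urea end carries over to the compound without the (4-(methylsulfonyl)piperazin-1-yl)methyl group. Also open, on these data alone, is what other groups on this carbon would give, such as a dimethylaminomethyl group, a morpholin-4-ylmethyl group or a piperazin-1-ylmethyl group lacking the methylsulfonyl part.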